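This account rests on a few compounds, and the source may have more. Where it says the series, first, only, none or still open, it means among the compounds named here.

Working notes on the series. In an assay on isolated protein for inhibition of matrix metalloproteinase-9 (Homo sapiens) (on this read-out lower numbers stand for stronger inhibition and higher numbers for weaker inhibition), compound 1 `COc1ccc(COC(=O)c2cccc(S)n2)cc1` gives 95000 nM, and compound 2 `O=C(OC1CCC1)c1cccc(=O)[nH]1` gives 62000 nM. Only these two numbers exist so far, and they lie within the scatter of each other, so no order between compound 1 and compound 2 can be claimed. Compound 3 `O=C(Oc1cccs1)c1cccc(=O)[nH]1` carries the change (thiophen-2-yl in place of cyclobutyl on an oxygen next to a carbonyl group). Among the measured compounds shown here, no measured step of this kind is at hand, so the expected change in this assay is put at little beyond the scatter, with direction open. For compound 3 the estimate is 50000 nM, within 15000 nM to 150000 nM, a step of a 1.2-fold lower number from compound 2 to compound 3 (0.09 log units; within the scatter).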

Compound 3, half-maximal inhibitory concentration: 70000 nM
Estimate against measurement, compound 3: 1.4-fold (0.15 log units) below, and the stated range covers the measured number.
By their numbers in this assay, from the lowest: compounds 2, 3 and 1 (each within the scatter of the next).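

In this assay, thiophen-2-yl in place of cyclobutyl on an oxygen next to a carbonyl group gives a 1.1-fold higher number from compound 2 to compound 3 (0.05 log units; within the scatter) and so no readable change. The two groups, one a four-membered non-aromatic ring of carbon only and the other a five-membered aromatic ring with a hetero atom, cannot be told apart at this position on this read-out. Nothing at hand bears on why the step is this small.

From the compounds shown here alone, whether an amine, a carboxylic acid or a longer chain on this oxygen would move the number beyond the scatter remains open.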